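The source may report more compounds than this note shows. Statements on the series, on what has been measured and on what is new or still open speak of the compounds shown alone.

Measured compounds in a functional assay on MCF7 cells (Homo sapiens) for antiproliferative activity, read by sulforhodamine B assay, with a stated time of 48 h; on this read-out lower numbers stand for stronger inhibition and higher numbers for weaker inhibition:
- compound 1 `CC(C)c1ccccc1OS(=O)(=O)c1cccc(NC(=O)C(C)(C)C)c1` gives 14000 nM
- compound 2 `CC(C)c1ccccc1OS(=O)(=O)c1ccc(NC(=O)CCl)cc1` gives 2900 nM
- compound 3 `O=C(CCl)Nc1ccc(S(=O)(=O)Oc2ccccc2I)cc1` gives 2500 nM

Compound 3 has the lowest number of the three, but its distance to compound 2 is within the scatter, so the two cannot be told apart; only compound 1 stands clearly apart from it, with a higher number. Among the compounds with values here, the one single-point step measured here, a 1.2-fold lower number from compound 2 to compound 3 (0.06 log units; within the scatter), swaps a group on the aromatic ring that carries the sulfonate and leaves the amide side untouched.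

Compound 4 `O=C(Nc1ccc(S(=O)(=O)Oc2ccccc2I)cc1)NC1CC1` differs from compound 3 on that amide side: cyclopropylamino in place of chloromethyl on a carbonyl carbon. Within the data shown here, no measured step isolates a change at this position. Compound 1 carries a different, bulkier acyl group than compound 2, yet the two also differ in where the amide sits on its ring, so their values speak only loosely to the question; what they show is a clearly higher number for compound 1 than for compound 2. On that slim basis, moving away from the chloromethyl group is expected to cost activity, and a step of a 3.6-fold higher number from compound 3 to compound 4 (0.56 log units; beyond the scatter) is estimated. Compound 4 is therefore expected to give 9000 nM in this assay, within a range of 2500 nM to 30000 nM.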

Compound 4, half-maximal inhibitory concentration: 7400 nM
Compound 4: the middle estimate sits 1.2-fold (0.09 log units) above what was measured; the range from low to high includes it.
By their numbers in this assay, from the lowest: compounds 3 and 2 (each within the scatter of the next); then compounds 4 and 1 (each within the scatter of the next).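

Within the data shown here, putting cyclopropylamino in place of chloromethyl on a carbonyl carbon gives a 3.0-fold higher number from compound 3 to compound 4 (0.47 log units; beyond the scatter) in this assay, the first clean reading at this position, with the rest of the molecule unchanged and a shift toward weaker inhibition. The exchange removes the chlorine and brings in a nitrogen with its hydrogen-bond donor and a three-membered ring all at once, so this single step shows the combined outcome and cannot divide it among those parts. No measurement at hand offers an explanation for the shift.

The compounds shown leave open which part of the change carries the step: a plain methyl on the carbonyl carbon would speak to the chlorine, while methylamino and a cyclopropyl attached without the nitrogen would help separate the nitrogen from the ring. Going by these compounds, it also remains open whether the step would be the same size with isopropyl in place of iodo, since this exchange appears here only in the iodo series.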